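Piperidine substituent swap in a GIP receptor agonist series

The source may report more compounds than this note shows. Statements on the series, on what has been measured and on what is new or still open speak of the compounds shown alone.

Measured so far:
compound 1, `CC(C)(C)OC(=O)N1CCC(O[C@H]2CC[C@H](Oc3ccc(S(C)(=O)=O)cc3)CC2)CC1`: 115%
compound 2, `CC(C)S(=O)(=O)c1cnc(O[C@H]2CC[C@H](OC3CCN(C(=O)OC(C)(C)C)CC3)CC2)cn1`: 109%
compound 3, `CS(=O)(=O)c1cnc(O[C@H]2CC[C@H](OC3CCN(C(=O)OC4CCOC4)CC3)CC2)cn1`: 105%

All three compounds were tested in a functional assay on isolated protein for agonist activity at Glucose-dependent insulinotropic receptor (Homo sapiens), read by HTRF and cAMP accumulation; on this read-out higher numbers stand for larger maximal responses and lower numbers for smaller maximal responses. Compound 1 gives 115%, compound 2 gives 109%, and compound 3 gives 105%. Compound 3 carries the lowest of the three numbers, yet its gap to compound 2 and its gap to compound 1 both lie within the usual scatter, so the three values show no separation beyond noise: each compound reaches a full maximal response.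

Compound 4, `CC(C)c1noc(CN2CCC(O[C@H]3CC[C@H](Oc4cnc(S(C)(=O)=O)cn4)CC3)CC2)n1`, has not yet been measured. It differs from compound 3 in one place: (3-isopropyl-1,2,4-oxadiazol-5-yl)methyl in place of ((oxolan-3-yl)oxy)carbonyl on an amine nitrogen in a ring. Within the data shown here, no step between two measured compounds isolates this kind of change, so nothing measured here points to a shift in maximal response. Because compound 3 gives 105% in this assay, a number near the full response, compound 4 is expected to remain there, and the step of no change at the digits printed from compound 3 to compound 4 (within the scatter) is expected to stay within the scatter. Compound 4 is estimated at 105%, within a range of 85% to 120%.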

Compound 4, largest response reached (Emax), in percent of the reference or control that the assay uses: 102%
Compound 4: the middle estimate sits 3 percentage points above what was measured; the range from low to high includes it.
By their numbers in this assay, from the lowest: compounds 4, 3, 2 and 1 (each within the scatter of the next, the first and the last beyond it).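

In this assay, among these compounds, the step of a number 3 percentage points lower from compound 3 to compound 4 (within the scatter) is the first one here to isolate a single change, and it falls on the amine nitrogen of the six-membered ring. It shows that this nitrogen tolerates more than a group joined through a carbonyl: a (3-isopropyl-1,2,4-oxadiazol-5-yl)methyl group, with its five-membered aromatic ring and no double bond outside aromatic rings, keeps the maximal response of the ((oxolan-3-yl)oxy)carbonyl group. No measurement given here explains this tolerance.

The compounds shown leave open whether the maximal response would hold with a bare amine hydrogen, a benzyl group or a carboxylic acid on a short chain at this nitrogen. They also leave open whether an oxadiazole joined directly to the nitrogen, without the methyl link, would behave the same way.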